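The source may hold more compounds than are shown below. What is called first, only, known or untested is meant among the compounds shown, and "the series" means these compounds.

Measured so far:
Compound 1, `CCCCCCCCCCn1cc(-c2nc3ccccc3cc2CCCC)nn1` — in a functional assay on COLO 205 cells (Homo sapiens) for cytotoxicity, read by MTT assay, with a stated time of 24 h (a lower number here means a stronger inhibitor, a higher number a weaker inhibitor), compound 1 gives > 100 ug/mL, which is a limit of the assay and not a number.
Compound 2, `Cc1cc2ccccc2nc1-c1cn(-c2ccc(F)cc2)nn1` — in this assay compound 2 gives > 100 ug/mL, likewise only a limit.

Compound 1 therefore stands at a limit rather than at a measured number, and it cannot be ordered against compound 2, since both values sit at the limit of > 100 ug/mL in this assay, at which 2 of the 2 values shown sit. Nothing further is known of either. The step to compound 3, `CCCCCCCCCCn1cc(-c2nc3ccccc3cc2CCC)nn1`, shortens the butyl on the core of compound 1: hydrogen in place of methyl on a saturated chain carbon, three bonds along the chain from an aromatic carbon, the same difference cut one bond further out reading butyl to propyl. Among the compounds with values here, no step between measured compounds exists here, so there is no measured size to lean on. The expected step from compound 1 to compound 3 in this assay, a step that the limit leaves unreadable from compound 1 to compound 3, is none beyond the scatter. Compound 3 is thus estimated at about 150 ug/mL, within 60 ug/mL to 400 ug/mL, and most probably reported again only as a limit.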

Compound 3, half-maximal inhibitory concentration: > 100 ug/mL
Compound 3: a limit, no number (the forecaster's own chance of this, stated with the estimate: 85%); the middle value lies beyond the limit too.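

No step can be read from compound 1 to compound 3, since both stand only at a limit and not at a number: the limit of > 100 ug/mL in this assay, at which 3 of the 3 values shown sit.

The compounds shown leave open whether any change to the shared core would give a measured number in this assay.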